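The source may hold more compounds than are shown below. What is called first, only, known or untested is meant among the compounds shown, and "the series" means these compounds.

In an assay on isolated protein for inhibition of acid ceramidase (Homo sapiens), read by LC-MS, with a stated time of 1 h (a higher number here means a weaker inhibitor, a lower number a stronger inhibitor), compound 1 `O=C(NCCCCc1ccccc1)n1cc(-c2ccccc2)oc1=O` gives 90 nM; compound 2 `CCCCCNC(=O)n1cc(-c2ccccc2)oc1=O` gives 39 nM and compound 3 `CCOCCNC(=O)n1cc(-c2ccccc2)oc1=O` gives 2040 nM, so compound 1 stands second highest of the three. Compound 4 `O=C(NCCCCc1ccccc1)n1cc(-c2ccc(F)cc2)oc1=O` differs from compound 1 by fluoro in place of hydrogen on an aromatic carbon, a change on the aromatic ring attached to the shared core. The steps seen so far all alter the chain on the amide-type nitrogen: a 2.3-fold lower number from compound 1 to compound 2 (0.36 log units; beyond the scatter) was modest, while a 23-fold higher number from compound 1 to compound 3 (1.36 log units; beyond the scatter) and a 52-fold higher number from compound 2 to compound 3 (1.72 log units; beyond the scatter) were large. None of them touches the aromatic ring, so they give no direct guidance, and a step no larger than the scatter is expected in this assay. For compound 4 the estimated value is 80 nM, within 30 nM to 250 nM, which as a step means a 1.1-fold lower number from compound 1 to compound 4 (0.05 log units; within the scatter) is expected.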

Compound 4, half-maximal inhibitory concentration: 185 nM
Compound 4: the middle estimate sits 2.3-fold (0.36 log units) below what was measured; low and high end bracket the measured number.
By their numbers in this assay, from the lowest: compound 2; then compound 1; then compound 4; then compound 3.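

In this assay, among the compounds shown here, the aromatic ring on the shared core turns out to matter, which no earlier step could show: fluoro in place of hydrogen, para to a large group, gives a 2.1-fold higher number from compound 1 to compound 4 (0.31 log units; beyond the scatter). A change of one atom here thus produces a modest step, smaller than the large steps seen on the chain on the amide-type nitrogen. Nothing measured here bears on why the number rose. On these data alone, whether chloro or methoxy at the same place would behave like fluoro remains open. So does whether phenyl to 4-fluorophenyl would give a similar step on compound 2, with its shorter chain.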